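From nitrile to phenyl on the pendant ring

The source may report more compounds than this note shows. Statements on the series, on what has been measured and on what is new or still open speak of the compounds shown alone.

Compound 3 `N#Cc1ccc(-c2scc3c2C2(CCN(Cc4ccccc4)CC2)OC3=O)cc1` was tested in an assay on membranes from brain for displacement of a labelled ligand from Sigma non-opioid intracellular receptor 1 (Cavia porcellus), read by scintillation counting, with a stated time of 120 min (a higher number here means a weaker inhibitor, a lower number a stronger inhibitor), where compound 3 gives 190 nM. Of the three measured numbers this is the second highest: compound 2 `COc1ccc(-c2sc(-c3ccc(OC)cc3)c3c2C(=O)OC32CCN(Cc3ccccc3)CC2)cc1` gives 158 nM, within the scatter of compound 3, whereas compound 1 `O=C1OC2(CCN(Cc3ccccc3)CC2)c2c1csc2-c1ccccc1` gives 483 nM. Going by the values given here, the one step into compound 3 is a 2.5-fold lower number from compound 1 to compound 3 (0.41 log units; beyond the scatter). Compound 4 `O=C1OC2(CCN(Cc3ccccc3)CC2)c2c1csc2-c1ccc(-c2ccccc2)cc1` differs from compound 3 by phenyl in place of cyano on an aromatic carbon. Among the compounds with values here, no measured step covers this swap directly; the only bearing on it is a 2.5-fold lower number from compound 1 to compound 3 (0.41 log units; beyond the scatter), which shows that placing a group at this position moved the number modestly downward. The step in this assay from compound 3 to compound 4 is therefore expected to be a 1.5-fold lower number from compound 3 to compound 4 (0.16 log units; within the scatter). Compound 4 is estimated at 130 nM, between 45 nM and 400 nM.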

Compound 4, inhibition constant: 402 nM
For compound 4 the middle estimate is 3.1-fold (0.49 log units) below the measured one; the measured number lies above the stated range.
By their numbers in this assay, from the lowest: compounds 2 and 3 (each within the scatter of the next); then compounds 4 and 1 (each within the scatter of the next).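

Phenyl in place of cyano gives a 2.1-fold higher number from compound 3 to compound 4 (0.33 log units; beyond the scatter) in this assay and a 1.2-fold lower number from compound 1 to compound 4 (0.08 log units; within the scatter) when phenyl replaces hydrogen on the same carbon. So putting a group at this place does not by itself lower the number: the nitrile of compound 3 does so, while the phenyl of compound 4 does not. Nothing measured here explains this difference between the two groups. On these data alone, what stays open is how an amine or a carboxylic acid at this place would read, and whether any group could go lower than the nitrile.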